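A few compounds are considered here, and "the series" means these few. Any claim that something is new, unique, unknown or untested is made for them only; others in the source may bear on it.

Measured compounds in the series:

compound 1 `CCCN(CCC)CCn1c2ccc3ccccc3c2c2nc3ccccc3nc21`, 15800 nM
compound 2 `c1ccc2c(c1)ccc1c2c2nc3ccccc3nc2n1CCN1CCCCC1`, 30900 nM
compound 3 `CC1CCN(CCn2c3ccc4ccccc4c3c3nc4ccccc4nc32)CC1`, 33100 nM

All three were tested in an assay on nucleic acid for binding affinity to Calf thymus DNA (Bos taurus); a lower number here means a stronger inhibitor, a higher number a weaker inhibitor. Going by the values given here, compound 3 gives the highest of the three numbers, though its gap to compound 2 is within the scatter; only the step of a 2.1-fold higher number from compound 1 to compound 3 (0.32 log units; beyond the scatter) reaches beyond it, and that only modestly.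

Compound 4 `CN1CCN(CCn2c3ccc4ccccc4c3c3nc4ccccc4nc32)CC1` differs from compound 3 in one place: 4-methylpiperazin-1-yl in place of 4-methylpiperidin-1-yl on a saturated chain carbon, two bonds along the chain from an aromatic nitrogen. Among the compounds with values here, the steps that bear on this are those that vary the amine at the same place: a 2.0-fold higher number from compound 1 to compound 2 (0.29 log units; within the scatter) and a 2.1-fold higher number from compound 1 to compound 3 (0.32 log units; beyond the scatter). Both are small, and the step of a 1.1-fold higher number from compound 2 to compound 3 (0.03 log units; within the scatter), a methyl on the ring, is negligible. The amine at this position has so far moved this assay only slightly, so a change to 4-methylpiperazin-1-yl is expected to give a step of a 1.1-fold lower number from compound 3 to compound 4 (0.04 log units; within the scatter), with no clear direction beyond the scatter.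

Compound 4 is therefore estimated at 30000 nM, with a range of 12000 nM to 80000 nM.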

Compound 4, half-maximal inhibitory concentration: 14500 nM
Compound 4: the middle estimate sits 2.1-fold (0.32 log units) above what was measured; the range from low to high includes it.
By their numbers in this assay, from the lowest: compounds 4, 1, 2 and 3 (each within the scatter of the next, the first and the last beyond it).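

In this assay, the step of a 2.3-fold lower number from compound 3 to compound 4 (0.36 log units; beyond the scatter) shows that a change of atom within the ring can move the number beyond the scatter at equal heavy-atom count, whereas the added ring methyl of a 1.1-fold higher number from compound 2 to compound 3 (0.03 log units; within the scatter) stayed within it. The step of a 2.1-fold lower number from compound 2 to compound 4 (0.33 log units; beyond the scatter) is of similar modest size, while a 1.1-fold lower number from compound 1 to compound 4 (0.04 log units; within the scatter) stays within the scatter, so a cyclic amine at this place does not by itself give a higher number than dipropylamino: compounds 2 and 3 lie higher than compound 1 by small steps, and compound 4 goes against that trend. No evidence is available to explain these differences.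

Going by these compounds, whether morpholin-4-yl or piperazin-1-yl would track with compound 4 or with compound 3 remains open. Also open, on these data alone, is how 4-methylpiperazin-1-yl behaves on a longer chain than the 2-substituted ethyl.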